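Second chloro on the purine core of compound 3

This account rests on a few compounds, and the source may have more. Where it says the series, first, only, none or still open, it means among the compounds named here.

Compound 3 `ClCc1ccccc1Cn1cnc2ncnc(Cl)c21` carries a single chloro group on its fused core. In a functional assay on LOX IMVI cells (Homo sapiens) for cytotoxicity, read by sulforhodamine B assay, with a stated time of 48 h (a lower number here means a stronger inhibitor of growth, a higher number a weaker inhibitor of growth), compound 3 gives 3090 nM, the lowest of the three numbers recorded, though the gap to its neighbours is within the scatter. Compound 1 `ClCc1ccc(Cn2cnc3nc(Cl)nc(Cl)c32)cc1` gives 3230 nM and compound 2 `ClCc1cccc(Cn2cnc3c(Cl)nc(Cl)nc32)c1` gives 3380 nM in this assay; both carry two chloro groups on the core, and their numbers sit within the scatter of compound 3, so no ordering among the three can be read.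

Compound 4 `ClCc1ccccc1Cn1cnc2nc(Cl)nc(Cl)c21` is the direct counterpart of compound 3 with chloro in place of hydrogen on an aromatic carbon, placed between two ring nitrogen atoms, meta to a chloro group, meta to a fused ring and para to a fused ring. Among the measured compounds shown here, no measured pair in this set isolates that change. Since compound 1, holding this second chloro on one differently substituted benzyl arm, gives 3230 nM and compound 2, holding it on another, gives 3380 nM, the step from compound 3 to compound 4 is expected to be a 1.0-fold higher number from compound 3 to compound 4 (0.00 log units; within the scatter), not beyond the scatter in either direction. Compound 4 is therefore estimated at 3100 nM, with a likely range from 1500 nM to 6500 nM in this assay.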

Compound 4, concentration for total growth inhibition: 350 nM
Beside the measured number, compound 4's estimate is 8.9-fold (0.95 log units) above it; measured number outside the range, below it.
By their numbers in this assay, from the lowest: compound 4; then compounds 3, 1 and 2 (each within the scatter of the next).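

Placing chloro in place of hydrogen on the aromatic carbon between two ring nitrogen atoms gives an 8.8-fold lower number from compound 3 to compound 4 (0.95 log units; beyond the scatter) in this assay, so this position, untested by any earlier pair, responds to the change. The step is tied to the benzyl arm of compound 4: compound 1, with the same two chloro groups on the core but its chloromethyl group placed differently on the arm, gives 3230 nM, whereas compound 4 gives 350 nM. Nothing available explains the step or why the arm matters.

The compounds shown do not reveal whether the response is specific to chloro, since no amine, methoxy or fluoro group appears at this carbon. They also leave open whether the step would hold in other cell lines.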